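This account rests on a few compounds, and the source may have more. Where it says the series, first, only, none or still open, it means among the compounds named here.

Measured so far in a functional assay on A-431 cells (Homo sapiens) for cytotoxicity; on this read-out lower numbers stand for an effect already at smaller amounts and higher numbers for an effect only at larger amounts of compound:

compound 1 `COC1=C(C)C(=O)/C(=C(O)/C=C/c2ccccc2C)C(=O)C1(C)C`: 5.2 ug/mL
compound 2 `COC1=C(C)C(=O)/C(=C(O)/C=C/c2c(C)cccc2C)C(=O)C1(C)C`: 10.1 ug/mL
compound 3 `CCC1=C(OC)C(CC)(CC)C(=O)C(C(=O)/C=C/c2ccccc2)=C1O`: 5.4 ug/mL

Compound 2 differs from compound 1 by methyl in place of hydrogen on an aromatic carbon, and this gave a 1.9-fold higher number from compound 1 to compound 2 (0.29 log units; within the scatter). Compound 4 `CCC1=C(OC)C(CC)(CC)C(=O)C(C(=O)/C=C/c2ccc(C)cc2)=C1O`, not yet measured, differs from compound 3 by methyl in place of hydrogen on an aromatic carbon. This is the same kind of change, but the place is not the same: in compound 2 the methyl sits ortho to a large group and meta to a methyl group, in compound 4 para to a large group. The difference between the core of compound 1 and the core of compound 3 is not broken down here; the two compounds themselves give numbers within the scatter of each other.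

Within the data shown here, for compound 4 the step of a 1.4-fold higher number from compound 3 to compound 4 (0.14 log units; within the scatter) is expected, a change of about the size seen in a 1.9-fold higher number from compound 1 to compound 2 (0.29 log units; within the scatter), since that is the only measured instance of this kind of change. Compound 4 is thus estimated at 7.5 ug/mL, between 3.5 ug/mL and 16 ug/mL.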

Compound 4, concentration for half-maximal effect: 10.3 ug/mL
Estimate against measurement, compound 4: 1.4-fold (0.14 log units) below; measured number inside the range.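

In this assay, methyl in place of hydrogen on an aromatic carbon gave a 1.9-fold higher number from compound 3 to compound 4 (0.28 log units; within the scatter), and the change reads alike on the two cores: the same change on two cores in this assay, a 1.9-fold higher number (0.29 log units; within the scatter) from compound 1 to compound 2 and a 1.9-fold higher number (0.28 log units; within the scatter) from compound 3 to compound 4, 1.0-fold (0.01 log units) apart, within the scatter of two such steps. Among these compounds, both steps lie within the scatter, which shows only that the change stays within the scatter on each core, not that the methyl has a real effect on the number. The two instances also differ in the place of the methyl, and these compounds do not separate place from core.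

Open, on these data alone, is whether an amine or a carboxylic acid in place of the methyl would give a step beyond the scatter. Also open, as far as these compounds go, is whether a longer chain on the core would alter how this change carries over.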